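A few compounds are considered here, and "the series" means these few. Any claim that something is new, unique, unknown or untested is made for them only; others in the source may bear on it.

Measured compounds in an ADME assay on MRC5 cells (Homo sapiens) for inhibition, with a stated time of 72 h; on this read-out higher numbers stand for an effect only at larger amounts of compound and lower numbers for an effect already at smaller amounts:
compound 1 `CO[C@H]1CC[C@H](NC(=O)c2n[nH]cc2NC(=O)c2cnc3ccccn23)CC1`: 5900 nM
compound 2 `COc1cccc(OC)c1C(=O)Nc1c[nH]nc1C(=O)NC1CCCCCC1`: 42000 nM
compound 3 `COc1ccccc1C(=O)Nc1c[nH]nc1C(=O)N[C@H]1CC[C@H](OC)CC1`: 1500 nM

Compound 2 stands at the highest number of the three in this assay, beyond the scatter from both compound 1 and compound 3. Going by the values given here, the only measured step is a 3.9-fold lower number from compound 1 to compound 3 (0.59 log units; beyond the scatter); it concerns the group on the carbonyl carbon of the other amide and leaves the amide-type nitrogen of interest untouched. Compound 4 `COc1cccc(OC)c1C(=O)Nc1c[nH]nc1C(=O)NCc1ccccc1` differs from compound 2 by benzyl in place of cycloheptyl on an amide-type nitrogen. Among the compounds with values here, no measured pair shows this exchange, and the step from compound 1 to compound 3 does not bear on it, so the expectation rests on compound 2 alone. Within the data shown here, with nothing pointing in either direction, the step of a 1.1-fold lower number from compound 2 to compound 4 (0.02 log units; within the scatter) is estimated to lie within the scatter, with a wide range to allow for an exchange that has no precedent in this set. Compound 4 is expected at about 40000 nM, between 12000 nM and 130000 nM.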

Compound 4, half-maximal effective concentration: 50000 nM
Estimate against measurement, compound 4: 1.3-fold (0.10 log units) below; low and high end bracket the measured number.
By their numbers in this assay, from the lowest: compound 3; then compound 1; then compounds 2 and 4 (each within the scatter of the next).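

Benzyl in place of cycloheptyl on an amide-type nitrogen gives a 1.2-fold higher number from compound 2 to compound 4 (0.08 log units; within the scatter) in this assay and is the first change at this place in the series. A seven-membered non-aromatic ring of carbon only can therefore give way to a six-membered aromatic ring of carbon only, at an equal count of heavy atoms, without a shift beyond the scatter. The reading holds for the remainder of the structure shared by this pair and for this read-out alone, and no available evidence bears on the result.

Open, on these data alone, is whether the same exchange reads alike with the other groups on the carbonyl carbon of the second amide seen. Also open, as far as these compounds go, is how this place responds to an amine, a carboxylic acid or a longer chain on the amide-type nitrogen.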